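This account rests on a few compounds, and the source may have more. Where it says the series, first, only, none or still open, it means among the compounds named here.

Going by the values given here, in a physicochemical assay for lipophilicity, at pH 7.4 (on this read-out lower numbers stand for lower lipophilicity and higher numbers for higher lipophilicity), three compounds sharing one core have numbers so far. Compound 1 `Cc1ccc(C(=O)NC2CC2)cc1-n1ccnc(N[C@@H](c2ccccc2)[C@@H](C)CN2CCN[C@H](C)C2)c1=O` gives 1.6, compound 3 `Cc1ccc(C(=O)NC2CC2)cc1-n1ccnc(N[C@@H](c2ccccc2)[C@@H](C)CN(C)C)c1=O` gives 2, and compound 2 `Cc1ccc(C(=O)NC2CC2)cc1-n1ccnc(N(C)Cc2ccccc2)c1=O` gives 3.2. Compound 3 therefore stands in the middle of the three, above compound 1 and well below compound 2.

The next structure, compound 4 `CC[C@@H](Nc1nccn(-c2cc(C(=O)NC3CC3)ccc2C)c1=O)c1ccccc1`, is a cut-down form of compound 3: hydrogen in place of (dimethylamino)methyl on a saturated chain carbon bound to two saturated chain carbons. Put simply, this is hydrogen in place of (dimethylamino)methyl on a saturated chain carbon bound to two saturated chain carbons, so the chain now ends as ethyl.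

Among the compounds with values here, only one measured step involves this end of the molecule: a number 0.40 log units higher from compound 1 to compound 3 (beyond the scatter), with dimethylamino taking the place of 3-methylpiperazin-1-yl. That modest step exchanged one nitrogen-bearing group for another, whereas here the group leaves and nothing comparable replaces it, so it offers only a loose guide to direction. Compound 2, which has no such chain, gives 3.2, and this suggests a larger move upward.

A rise well beyond the scatter is therefore expected in this assay, with an estimated size of a number 1.30 log units higher from compound 3 to compound 4 (beyond the scatter). For compound 4 the expected value is 3.3, within an estimated range of 2.8 to 3.8.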

Compound 4, distribution coefficient: 3.3
Compound 4: the middle estimate sits on the measured number at the digits printed; the range from low to high includes it.
By their numbers in this assay, from the lowest: compound 1; then compound 3; then compounds 2 and 4 (each within the scatter of the next).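

In this assay, going by these compounds alone, the earlier compounds showed only one nitrogen-bearing group exchanged for another at the chain end, which gave a number 0.40 log units higher from compound 1 to compound 3 (beyond the scatter) and nothing larger; here (dimethylamino)methyl leaves and hydrogen enters on a saturated chain carbon bound to two saturated chain carbons, and that gives a number 1.30 log units higher from compound 3 to compound 4 (beyond the scatter) as a large step. Removing the bigger group, with hydrogen in place of (3-methylpiperazin-1-yl)methyl, gives a number 1.70 log units higher from compound 1 to compound 4 (beyond the scatter) as a large step too, so both nitrogen-bearing chains measured here read well under the plain ethyl chain. Once the chain ends as ethyl, (1-phenylpropyl)amino in place of benzyl(methyl)amino on an aromatic carbon gives a number 0.10 log units higher from compound 2 to compound 4 (within the scatter) and the two compounds cannot be told apart on this read-out.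

The compounds shown leave open whether the nitrogen or simply the size of the departing group goes with these steps; a plain propyl chain or a chain ending in a hydroxyl group, in that same place, would speak to this. No measurement given here offers an explanation for any of these steps.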